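The source may report more compounds than this note shows. Statements on the series, on what has been measured and on what is new or still open speak of the compounds shown alone.

Of the compounds shown here, three sharing one core have so far been tested in an assay on membranes from HEK293 cells for displacement of a labelled ligand from adenosine receptor A2b (Homo sapiens), read by scintillation counting, with a stated time of 30 min, tested at 1 uM; a lower number here means less inhibition, a higher number more inhibition at the concentration tested (going by the name of the read-out). Compound 1 `CCCOC(=O)C1=C(C)N(C)C(=O)NC1c1ccco1` gives 23%, compound 2 `CCCOC(=O)C1=C(C)N(C)C(=O)NC1c1cccs1` gives 1%, and compound 3 `COC(=O)C1=C(C)N(C)C(=O)NC1c1ccsc1` gives 26%. Among these, compound 3 holds the largest number, although compound 1 lies within the usual scatter of it; only compound 2 falls clearly beyond the scatter, on the lower side. For the measured compounds named here, the one step between measured compounds that differ in a single place, a number 22 percentage points lower from compound 1 to compound 2 (beyond the scatter), concerns thiophen-2-yl in place of furan-2-yl on a saturated ring carbon.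

Compound 4 `CCCOC(=O)C1=C(C)N(C)C(=O)NC1c1ccsc1` has not yet been measured in this assay. It differs from compound 3 in one place: ethyl in place of hydrogen on a saturated chain carbon bound to an oxygen next to a carbonyl group Put another way, methoxycarbonyl becomes propoxycarbonyl. Going by the values given here, no measured pair differs solely in this way; compounds 1 and 2 already carry the propoxy chain and compound 3 the methoxy, but each of them also differs from compound 3 at the ring attached to the saturated ring carbon. Among the compounds with values here, the single measured step bears on that ring, not on the chain, and so offers no direct guide here. Within the data shown here, with no comparable step available, no change beyond the scatter is expected, no change at the digits printed from compound 3 to compound 4 (within the scatter). Compound 4 is accordingly estimated at 26%, within a range from 8% to 44%.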

Compound 4, a percentage reported as inhibition, at one concentration (the size of the read-out at that concentration, not a potency): 1%
Estimate against measurement, compound 4: 25 percentage points above; measured number below the stated range.
By their numbers in this assay, from the lowest: compounds 2 and 4 (each within the scatter of the next); then compounds 1 and 3 (each within the scatter of the next).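

In this assay the change from methoxycarbonyl to propoxycarbonyl, ethyl in place of hydrogen on a saturated chain carbon bound to an oxygen next to a carbonyl group, can now be read directly, and it gives a number 25 percentage points lower from compound 3 to compound 4 (beyond the scatter), so this chain position is not indifferent when thiophen-3-yl is the ring on the saturated ring carbon. With the propoxy chain held constant, thiophen-3-yl in place of thiophen-2-yl gives no change at the digits printed from compound 2 to compound 4 (within the scatter), so these two thiophene attachments are not told apart here, whereas thiophen-3-yl in place of furan-2-yl gives a number 22 percentage points lower from compound 1 to compound 4 (beyond the scatter). Among the three propoxycarbonyl compounds, the furan-2-yl compound 1 therefore stands clear of the other two, which sit together at the low end of the read-out.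

As far as these compounds go, whether the step from methoxycarbonyl to propoxycarbonyl holds with furan-2-yl or thiophen-2-yl on the ring remains open, as does where an ethoxycarbonyl group, a longer butoxycarbonyl chain or a carboxylic acid would fall. Nothing available gives a reason for any of these steps.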